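Trifluoromethyl for methyl on an oxime ether

The source may hold more compounds than are shown below. What is called first, only, known or untested is meant among the compounds shown, and "the series" means these compounds.

Measured compounds:
- compound 1, `O=[N+]([O-])c1ccc2c(c1)/C(=N\O)C(c1c[nH]c3ccc([N+](=O)[O-])cc13)=N2`, gives 13200 nM in a functional assay on T-24 cells (Homo sapiens) for cytotoxicity, read by MTT assay, with a stated time of 2 days; on this read-out lower numbers stand for stronger inhibition and higher numbers for weaker inhibition
- compound 2, `Cc1ccc(CO/N=C2/C(c3c[nH]c4ccccc34)=Nc3ccccc32)cc1`, gives 23500 nM in this assay

Compound 2 stands with the highest of the two numbers in this assay, but its nearest neighbour, compound 1, lies within the usual scatter of it, so the two values show no difference that can be trusted.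

Compound 3, `FC(F)(F)c1ccc(CO/N=C2/C(c3c[nH]c4ccccc34)=Nc3ccccc32)cc1`, has not yet been measured. It differs from compound 2 in one place: trifluoromethyl in place of methyl on an aromatic carbon. Among the compounds with values here, no pair of measured compounds shows this change, so there is no step to lean on, and the expectation for compound 3 rests on compound 2 alone.

With nothing in the data to point either way, the step from compound 2 to compound 3 in this assay is expected to stay near the scatter, estimated as a 1.3-fold lower number from compound 2 to compound 3 (0.12 log units; within the scatter). Compound 3 is therefore expected to give about 18000 nM in this assay, estimated to fall between 6000 nM and 50000 nM.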

Compound 3, half-maximal inhibitory concentration: 18900 nM
Beside the measured number, compound 3's estimate is 1.1-fold (0.02 log units) below it; the measured number falls inside the stated range.
By their numbers in this assay, from the lowest: compounds 1, 3 and 2 (each within the scatter of the next).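

In this assay, within the data shown here, this is the first step that can be read at this position: the change from 4-methylphenyl to 4-(trifluoromethyl)phenyl gives a 1.2-fold lower number from compound 2 to compound 3 (0.09 log units; within the scatter) and so lies within the scatter. Among these compounds, putting four heavy atoms where there was one, on an aromatic carbon para to a large group, therefore yields two values that cannot be told apart, something the earlier compounds could not show because they differ from each other in more than one place. Nothing measured here offers an explanation for this result.

The compounds shown leave open whether a different group at this position, such as an amine, a carboxylic acid or a longer chain, would give a step beyond the scatter in this assay and in which direction. They also leave open whether the change from methyl to trifluoromethyl would behave the same way on a core carrying the nitro groups of compound 1.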